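A few compounds are considered here, and "the series" means these few. Any claim that something is new, unique, unknown or untested is made for them only; others in the source may bear on it.

Measured so far in a functional assay on HepG2 cells (Homo sapiens) for antiproliferative activity, read by XTT assay, with a stated time of 72 h; a higher number here means a weaker inhibitor, a lower number a stronger inhibitor:
Compound 1 `COc1nc(N)nc2c1c(-c1ccco1)cn2[C@@H]1O[C@H](CO)[C@@H](O)[C@H]1O`: > 20000 nM
Compound 2 `COc1nc(N)nc2c1c(-c1ccoc1)cn2[C@@H]1O[C@H](CO)[C@@H](O)[C@H]1O`: > 20000 nM
Compound 3 `COc1nc(N)nc2c1c(-c1cccs1)cn2[C@@H]1O[C@H](CO)[C@@H](O)[C@H]1O`: > 20000 nM

Compound 3 stands at > 20000 nM, which is a limit and not a number. The same holds across the series, which shows only (the limit of > 20000 nM in this assay, at which 3 of the 3 values shown sit). Compound 4 `COc1nc(N)nc2c1c(-c1ccsc1)cn2[C@@H]1O[C@H](CO)[C@@H](O)[C@H]1O` keeps the shared core and carries thiophen-3-yl in place of thiophen-2-yl on an aromatic carbon. The closest parallel is the exchange of furan-2-yl for furan-3-yl, a step that the two limits leave unreadable from compound 1 to compound 2. Among the measured compounds shown here, the two other measured steps, a step that the two limits leave unreadable from compound 1 to compound 3 and a step that the two limits leave unreadable from compound 2 to compound 3, also change only this group. None of the three has a readable size, so they give no direction. In this assay, no step beyond the scatter is expected, and compound 4 will most likely also return only a limit. The expected step that the limit leaves unreadable from compound 3 to compound 4 is an estimate resting on limits alone. The estimated value for compound 4 is 30000 nM, with an expected range from 12000 nM to 70000 nM.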

Compound 4, half-maximal inhibitory concentration: > 20000 nM
Compound 4: a limit, no number (the forecaster's own chance of this, stated with the estimate: 90%); the middle value lies beyond the limit too.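

In this assay, among the compounds shown here, compound 4 gives > 20000 nM, which is a limit and not a number, so no step from compound 1, compound 2 or compound 3 to compound 4 can be read. The compounds shown leave open whether furan-2-yl, furan-3-yl, thiophen-2-yl and thiophen-3-yl differ at all in this assay, and the series offers no number to decide it: the limit of > 20000 nM in this assay, at which 4 of the 4 values shown sit.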